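A few compounds are considered here, and "the series" means these few. Any claim that something is new, unique, unknown or untested is made for them only; others in the source may bear on it.

Working notes on the series. Compound 1 `CC(C)(C)OC(=O)N1CCC[C@@H]1C(=O)N1CCC(NS(=O)(=O)c2cc(S(=O)(=O)c3ccccc3)ccc2C(F)(F)F)CC1` in an assay on isolated protein for binding affinity to secreted frizzled-related protein 1 (Homo sapiens), read by fluorescence (a lower number here means a stronger inhibitor, a higher number a weaker inhibitor), gives 120 nM. Compound 2 `O=C([C@@H]1CCCN1C(=O)c1ccncc1)N1CCC(NS(=O)(=O)c2cc(S(=O)(=O)c3ccccc3)ccc2C(F)(F)F)CC1` in this assay gives 70 nM; the two numbers lie within the usual scatter of each other, so neither stands apart. Among the measured compounds shown here, no single-change step between measured compounds is available to lean on.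

Compound 3 `CC(C)(C)CCN1CCC[C@H]1C(=O)N1CCC(NS(=O)(=O)c2cc(S(=O)(=O)c3ccccc3)ccc2C(F)(F)F)CC1` differs from compound 1 by 1-(3,3-dimethylbutyl)pyrrolidin-2-yl in place of 1-(tert-butoxycarbonyl)pyrrolidin-2-yl on a carbonyl carbon. Nothing measured tests this change. Compound 3 is expected to show a step of a 1.7-fold higher number from compound 1 to compound 3 (0.22 log units; within the scatter), probably not beyond the scatter. The estimate for compound 3 in this assay is 200 nM, with a range from 60 nM to 700 nM.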

Compound 3, half-maximal inhibitory concentration: 30 nM
Compound 3: middle estimate off by 6.7-fold (0.82 log units), on the high side, outside the stated range (below it).
By their numbers in this assay, from the lowest: compound 3; then compounds 2 and 1 (each within the scatter of the next).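

In this assay the amine nitrogen in a ring accepts an alkyl group with no carbonyl: 3,3-dimethylbutyl gives a 2.3-fold lower number from compound 2 to compound 3 (0.37 log units; beyond the scatter) and also a 4.0-fold lower number from compound 1 to compound 3 (0.60 log units; beyond the scatter) and so separates from both acylated compounds, which the earlier pair could not do. The stereocentre is drawn in the opposite sense in compound 1, so the step from compound 2 is the cleaner reading. No measurement explains the gain.

From the compounds shown here alone, whether the branching or the chain length matters remains open, and a straight butyl chain or the free ring amine would bear on this.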